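Naphthylurea hydrazones: anticonvulsant dose series, halogen swap

This account rests on a few compounds, and the source may have more. Where it says the series, first, only, none or still open, it means among the compounds named here.

Measured so far:
compound 1 `COc1cccc(/C=N/NC(=O)Nc2cccc3ccccc23)c1` with 100 mg/kg
compound 2 `O=C(N/N=C/c1ccc(Br)cc1)Nc1cccc2ccccc12` with 300 mg/kg

In a functional assay on the whole organism (strain Swiss albino) with Mus musculus as the target, with a stated time of 0.5 h (a higher number here means that more compound is needed for the effect, a lower number that less compound is needed), compound 1 gives 100 mg/kg, whereas compound 2 gives 300 mg/kg. Among the compounds with values here, the single step between them, a 3.0-fold higher number from compound 1 to compound 2 (0.48 log units; beyond the scatter), changes the aryl on the hydrazone carbon. Compound 2 thus stands at the higher of the two numbers, with compound 1 the nearer and only comparator.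

Compound 3 `O=C(N/N=C/c1ccc(Cl)cc1)Nc1cccc2ccccc12` differs from compound 2 by chloro in place of bromo on an aromatic carbon. Within the data shown here, no measured step bears on this exchange of one halogen for another: the only step available, a 3.0-fold higher number from compound 1 to compound 2 (0.48 log units; beyond the scatter), changes both the halogen and its ring position together, and cannot be read as a guide to the chloro-for-bromo swap. With nothing to point either way, the expectation for compound 3 in this assay is a step of no change at the digits printed from compound 2 to compound 3 (within the scatter), that is, none beyond the scatter. The estimate for compound 3 is 300 mg/kg, within a range from 100 mg/kg to 1000 mg/kg.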

Compound 3, minimum effective dose: 300 mg/kg
Compound 3: middle estimate and measured number agree at the digits printed; the range from low to high includes it.
By their numbers in this assay, from the lowest: compound 1; then compounds 2 and 3 (each within the scatter of the next).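

In this assay, chloro in place of bromo on an aromatic carbon, para to a large group, gives no change at the digits printed from compound 2 to compound 3 (within the scatter), so at this position the minimum effective dose does not tell the two halogens apart, something the earlier pair could not show. The step of a 3.0-fold higher number from compound 1 to compound 3 (0.48 log units; beyond the scatter) shows that the gap to the 3-methoxyphenyl compound also holds with 4-chlorophenyl, although this step still changes both the group and its ring position. No supporting data accompany this result.

Still open, on these data alone, is whether the group or its ring position sets that gap, a question that 3-chlorophenyl and 4-methoxyphenyl analogues would separate. Also open, as far as these compounds go, is how an amine or a carboxylic acid in place of the halogen would read in this assay.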